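The compounds below may be only part of what the source reports. "The series", "measured", "known", "first", "only" and "open" are said of these compounds alone.

Compound 1 `Cc1ccccc1S(=O)(=O)c1ccc(NC(=O)C(C)(O)C(F)(F)F)cc1` gives 5100 nM in a functional assay (Cavia porcellus) with sulfonylurea receptors; K-ATP channels (Homo sapiens) as the target (on this read-out higher numbers stand for weaker inhibition and lower numbers for stronger inhibition), the lowest of the two numbers measured here, while compound 2 `CC(O)(C(=O)Nc1ccc(C(=O)c2ccccc2)cc1O)C(F)(F)F` gives 15000 nM, a higher number that lies beyond the usual scatter. Compound 3 `CC(O)(C(=O)Nc1ccc(S(=O)(=O)c2cncs2)cc1)C(F)(F)F` has not been measured yet; it differs from compound 1 in one place (1,3-thiazol-5-yl in place of 2-methylphenyl on a sulfonyl sulfur). Among the compounds with values here, no measured pair shows this particular exchange, so its effect is unknown from the data, and a step no larger than the usual scatter is expected, in either direction. On that basis compound 3 is expected to give 6000 nM, within 2500 nM to 15000 nM, which would mean an estimated step of a 1.2-fold higher number from compound 1 to compound 3 (0.07 log units; within the scatter).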

Compound 3, half-maximal inhibitory concentration: 7700 nM
The estimate for compound 3 lay 1.3-fold (0.11 log units) below the measured number, within the range that was stated.
By their numbers in this assay, from the lowest: compounds 1, 3 and 2 (each within the scatter of the next, the first and the last beyond it).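

On the sulfonyl sulfur in this assay, 1,3-thiazol-5-yl in place of 2-methylphenyl gives a 1.5-fold higher number from compound 1 to compound 3 (0.18 log units; within the scatter), so this exchange cannot be told apart from no change. A five-membered ring with two hetero atoms and two hydrogen-bond acceptors thus serves here about as well as a six-membered ring of carbon only, though this rests on one pair. No measurement at hand bears on why the number stays so close. Going by these compounds, whether a small methyl group or a ring carrying an amine or a carboxylic acid at this sulfur would shift the number beyond the scatter remains open.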